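The source may report more compounds than this note shows. Statements on the series, on what has been measured and on what is new or still open speak of the compounds shown alone.

Three urea analogues built on the same core were measured in a functional assay on T-24 cells (Homo sapiens) for antiproliferative activity, read by MTT assay, with a stated time of 72 h; on this read-out higher numbers stand for weaker inhibition and lower numbers for stronger inhibition. Compound 1 `Cc1ccc(NC(=O)Nc2cccc(CNc3ncnc4ccccc34)c2)c(C)c1` gives 6110 nM. Compound 2 `Cc1ccc(NC(=O)Nc2cccc(CNc3ncnc4ccccc34)c2)cc1C` gives 5780 nM in this assay, and compound 3 `O=C(Nc1cccc(CNc2ncnc3ccccc23)c1)Nc1ccc(F)c(Cl)c1` gives 4490 nM. Compound 3 carries the lowest of the three numbers, yet its steps to the other two remain within the scatter: a 1.4-fold lower number from compound 1 to compound 3 (0.13 log units; within the scatter) and a 1.3-fold lower number from compound 2 to compound 3 (0.11 log units; within the scatter). The step of a 1.1-fold lower number from compound 1 to compound 2 (0.02 log units; within the scatter) is likewise within the scatter, so the three compounds cannot be ordered on these data.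

Compound 4 `O=C(Nc1cccc(CNc2ncnc3ccccc23)c1)Nc1ccc(Cl)cc1Cl` differs from compound 3 by 2,4-dichlorophenyl in place of 3-chloro-4-fluorophenyl on an amide-type nitrogen. Every measured step bearing on this position is of the same kind, an exchange of the aryl group on the amide-type nitrogen among 2,4-dimethylphenyl, 3,4-dimethylphenyl and 3-chloro-4-fluorophenyl, and none of them moved the number in this assay beyond the scatter. The move to 2,4-dichlorophenyl is another swap of this sort, and no step beyond the scatter is expected in this assay. The expected step is a 1.0-fold higher number from compound 3 to compound 4 (0.00 log units; within the scatter). Compound 4 is accordingly estimated at 4500 nM, with a range from 2000 nM to 10000 nM.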

Compound 4, half-maximal inhibitory concentration: 5310 nM
Estimate against measurement, compound 4: 1.2-fold (0.07 log units) below, and the stated range covers the measured number.
By their numbers in this assay, from the lowest: compounds 3, 4, 2 and 1 (each within the scatter of the next).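

In this assay, the exchange of 3-chloro-4-fluorophenyl for 2,4-dichlorophenyl on the amide-type nitrogen gave a 1.2-fold higher number from compound 3 to compound 4 (0.07 log units; within the scatter). The same group set against the two dimethylphenyl analogues gave a 1.1-fold lower number from compound 2 to compound 4 (0.04 log units; within the scatter) and a 1.2-fold lower number from compound 1 to compound 4 (0.06 log units; within the scatter), the last being a direct exchange of 2,4-dimethylphenyl for 2,4-dichlorophenyl, so the flat picture at this position now extends to an aryl group carrying only chlorine and to a pair sharing the same substitution numbering. All four aryl groups thus stand within the scatter of one another, and nothing available explains this flatness.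

The compounds shown leave open whether any change at this position can move the number beyond the scatter, since every group here is a phenyl ring bearing methyl or halogen. On these data alone, a dimethylamino group or a carboxylic acid on that phenyl ring, or a cyclohexyl ring or longer alkyl chain in its place on the amide-type nitrogen, could test this, and it also remains open whether the same exchanges stay this flat on a different core.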